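The source may report more compounds than this note shows. Statements on the series, on what has been measured and on what is new or still open speak of the compounds shown alone.

Working notes on the series. The shared core is carried by compound 1 `COc1ccc(-n2nc(Sc3ccc(Cl)cc3)cc(CC[C@@H](C)NC(=O)[C@H]3CNCC[C@@H]3c3ccc(Cl)cc3)c2=O)cc1`, compound 2 `COc1ccc(-n2nc(Sc3ccc(Cl)cc3)cc(CC[C@@H](C)NC(=O)[C@H]3CNCC[C@@H]3c3ccccc3F)c2=O)cc1` and compound 3 `COc1ccc(-n2nc(Sc3ccc(Cl)cc3)cc(CC[C@@H](C)NC(=O)[C@H]3CCNC[C@@H]3c3ccc(Cl)cc3)c2=O)cc1`; compound 4 `COc1ccc(-n2nc(Sc3ccc(Cl)cc3)cc(CC[C@@H](C)NC(=O)[C@H]3CCNC[C@@H]3c3ccccc3F)c2=O)cc1` belongs to the same set and still awaits measurement. In an assay on CHO cells for binding affinity to Melanocortin receptor 4 (Homo sapiens) (on this read-out higher numbers stand for weaker inhibition and lower numbers for stronger inhibition), compound 1 gives 2.4 nM, compound 2 gives 13 nM and compound 3 gives 58 nM. Compound 3 stands at the highest number of the three measured: its number lies above that of compound 2 and further above that of compound 1, both gaps beyond the scatter.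

Compound 4 differs from compound 3 in one place: 2-fluorophenyl in place of 4-chlorophenyl on a saturated ring carbon. Among the measured compounds shown here, the one measured step that bears on this exchange is a 5.4-fold higher number from compound 1 to compound 2 (0.73 log units; beyond the scatter), the same swap made elsewhere. That step moved the number upward by a modest amount, beyond the scatter. With no other comparison available, a step of similar size and the same direction is expected here, namely a 5.2-fold higher number from compound 3 to compound 4 (0.71 log units; beyond the scatter). For the measured compounds named here, on that basis compound 4 is expected to give 300 nM in this assay, with a range from 100 nM to 900 nM, the width reflecting that only a single precedent step exists.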

Compound 4, half-maximal inhibitory concentration: 100 nM
Estimate against measurement, compound 4: 3.0-fold (0.48 log units) above; the measured number falls inside the stated range.
By their numbers in this assay, from the lowest: compound 1; then compound 2; then compounds 3 and 4 (each within the scatter of the next).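

In this assay, on the core of compound 3, replacing 4-chlorophenyl with 2-fluorophenyl on this saturated ring carbon gives a 1.7-fold higher number from compound 3 to compound 4 (0.24 log units; within the scatter), so on this core the two groups cannot be told apart on this read-out. The exchange therefore does not carry a fixed size across the series, and its size depends on the core that bears it: the same change on two cores in this assay, a 5.4-fold higher number (0.73 log units; beyond the scatter) from compound 1 to compound 2 and a 1.7-fold higher number (0.24 log units; within the scatter) from compound 3 to compound 4, 3.1-fold (0.50 log units) apart, beyond the scatter of two such steps. The larger step seen earlier, between compound 1 and compound 2, thus describes that core alone and cannot stand for the exchange in general.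

From the compounds shown here alone, the exchange swaps chlorine for fluorine and moves the halogen on the phenyl ring in a single change, so the share of each in the larger step stays open. Going by these compounds, a 4-fluorophenyl or a 2-chlorophenyl on both cores would separate the two, and whether a plain phenyl shows the same dependence on the core also remains open.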